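This account rests on a few compounds, and the source may have more. Where it says the series, first, only, none or still open, it means among the compounds named here.

Working notes on the series. In a physicochemical assay for solubility, read by HPLC, in phosphate buffer, measured as kinetic solubility, with a stated time of 1 h, at pH 7.4, tested at 250 uM (on this read-out higher numbers stand for higher solubility and lower numbers for lower solubility), compound 1 `CC(C)CNC(=O)n1c(=O)oc2ccc(C3CCN(C)CC3)cc21` gives 60000 nM and compound 2 `CC(C)N1CCC(c2ccc3c(c2)oc(=O)n3C(=O)NCCCCc2ccccc2)CC1` gives 50000 nM. Going by the values given here, these two values lie within the scatter of each other, so compound 2 stands level with compound 1 on the only two numbers at hand.

Compound 3 `CN1CCN(c2ccc3c(c2)oc(=O)n3C(=O)NCCCCc2ccccc2)CC1` keeps the rest of compound 2 and changes one place: 4-methylpiperazin-1-yl in place of 1-isopropylpiperidin-4-yl on an aromatic carbon. Among the compounds with values here, no pair of measured compounds isolates a change at this place, so the data give no direct size for it.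

Compound 1 and compound 2 differ at more than one place, yet their values do not separate beyond the scatter. On that thin basis, only a small step is expected in this assay, slightly upward if anything and probably not beyond the scatter. The estimated step of a 1.2-fold higher number from compound 2 to compound 3 (0.08 log units; within the scatter) is therefore small. For compound 3 the estimated value is 60000 nM, with an expected range of 30000 nM to 130000 nM.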

Compound 3, solubility: < 1000 nM
Compound 3 was reported as a limit; the forecaster's own chance of this, stated with the estimate: 5%; at least 60-fold (1.77 log units) between middle value and limit.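

Working notes, continued. In this assay, going by these compounds alone, this position proves sensitive: replacing 1-isopropylpiperidin-4-yl with 4-methylpiperazin-1-yl on the aromatic carbon gives an at least 50-fold lower number from compound 2 to compound 3 (1.69 log units; beyond the scatter), whereas no earlier pair isolated a change here. With the remainder of the structure held constant, the step is tied to this single exchange, which swaps a six-membered non-aromatic ring with 1 hetero atom for one with 2 hetero atoms and carries 7 heavy atoms in place of 9. The value of compound 3 is a limit of the assay and not a number, so the step gives only a bound and its full size cannot be read: the limit of < 1000 nM in this assay, at which 1 of the 3 values shown sits.

The compounds shown leave open whether the step follows the second ring nitrogen or the change from isopropyl to methyl on the ring, since both change together in this one exchange. A 4-isopropylpiperazin-1-yl group or a 1-methylpiperidin-4-yl group at this place, with the rest of compound 2 unchanged, would separate these two parts of the exchange.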